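The compounds below may be only part of what the source reports. "The series", "measured", "known", "first", "only" and "open" are said of these compounds alone.

Working notes on a small set of fused bicyclic amides tested in an assay on cells for displacement of a labelled ligand from adenosine receptor A1 (Homo sapiens), read by scintillation counting, with a stated time of 120 min, tested at 1 uM; on this read-out higher numbers stand for more inhibition at the one concentration tested (going by the name of the read-out) and lower numbers for less inhibition.

Compound 1 `O=C(Nc1nccn2cc(-c3ccccc3)nc12)c1cccnc1` gives 24% in this assay. Compound 3 `O=C(Nc1nc(-c2ccccc2)cn2cc(-c3ccccc3)nc12)c1cccnc1` carries one further group; the difference is phenyl in place of hydrogen on an aromatic carbon. The step of a number 13 percentage points lower from compound 1 to compound 3 (beyond the scatter) shows that adding the phenyl here cost measurable inhibition, with compound 3 giving 11%.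

Compound 2 `COc1ccc(-c2cn3ccnc(NC(=O)c4ccccc4)c3n2)cc1` is built on a different core, and the difference between the two cores is not broken down here. In this assay compound 2 gives 1%, which is the lowest of the three numbers: compound 3 stands close to it, within the scatter, while compound 1 stands clearly higher, beyond the scatter.

Compound 4 `COc1ccc(-c2cn3cc(-c4ccccc4)nc(NC(=O)c4ccccc4)c3n2)cc1` has not yet been measured. It differs from compound 2 by phenyl in place of hydrogen on an aromatic carbon. Among the compounds with values here, this is the same kind of change as the one from compound 1 to compound 3, though the surroundings differ in one respect: in compound 4 the new phenyl is meta to a benzamido group, whereas in compound 3 it is meta to a ((pyridin-3-yl)carbonyl)amino group.

Because compound 2 already gives 1%, and because the step of a number 13 percentage points lower from compound 1 to compound 3 (beyond the scatter) went downward, little room for a further drop remains, so the step from compound 2 to compound 4 is expected to be small, about no change at the digits printed from compound 2 to compound 4 (within the scatter). Compound 4 is therefore estimated to give about 1% in this assay, most likely between 0% and 9%.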

Compound 4, a percentage reported as inhibition, at one concentration (the size of the read-out at that concentration, not a potency): 3%
Compound 4: middle estimate off by 2 percentage points, on the low side, and the stated range covers the measured number.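

The new step is a number 2 percentage points higher from compound 2 to compound 4 (within the scatter), read in this assay for phenyl in place of hydrogen on an aromatic carbon. Set beside the earlier step, this shows that the change does not carry over from one core to the other in this series as a step of fixed size: the same change on two cores in this assay, a number 13 percentage points lower (beyond the scatter) from compound 1 to compound 3 and a number 2 percentage points higher (within the scatter) from compound 2 to compound 4, 15 percentage points apart, beyond the scatter of two such steps

Within the data shown here, this does not show which feature of the two cores accounts for the gap, since only two pairs are available and the cores are not broken down into single changes. It also leaves the size of the effect on the core of compound 2 poorly defined, as compound 2 at 1% and compound 4 at 3% lie so low on the read-out that a drop as large as the one on the core of compound 1 could not appear there.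

The compounds shown leave open how an amine, a carboxylic acid or a short alkyl chain would read in the place taken by the phenyl. They also leave open whether the phenyl step would hold on a further core with a higher starting number, and what the pyridin-3-yl and benzamido amide groups contribute when each is exchanged alone on one shared core.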